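A few compounds are considered here, and "the series" means these few. Any claim that something is new, unique, unknown or untested is made for them only; others in the source may bear on it.

Working notes on the series. In a functional assay on KG-1 cells (Homo sapiens) for cytotoxicity, read by luminescence and CellTiter-Glo, with a stated time of 3 days (a higher number here means a weaker inhibitor, a lower number a stronger inhibitor), compound 1, `N#Cc1ccc(NC(=O)c2cc(-c3ccncc3)ccc2O)cc1`, gives 7990 nM, the highest of the three numbers recorded so far. Compound 2, `O=C(Nc1ccc(C(F)(F)F)cc1)c1ccc(F)cc1O`, gives 740 nM, and compound 3, `O=C(Nc1ccc(Cl)c(Cl)c1)c1cc(F)ccc1O`, gives 760 nM; both gaps from compound 1 lie beyond the scatter, so compound 1 is the weakest inhibitor of the three measured. Compounds 2 and 3 share no single-point change with compound 1, so none of these gaps can be read as a step.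

Compound 4, `N#Cc1ccc(NC(=O)c2cc(-c3ccccc3)ccc2O)cc1`, is the next entry to be measured. It differs from compound 1 in one place: phenyl in place of pyridin-4-yl on an aromatic carbon. Among the compounds with values here, no step between measured compounds is available to set a size for this change, so the expectation rests on compound 1 alone. A small step toward a lower number, a somewhat stronger inhibitor, seems plausible, though a result within the scatter of compound 1 cannot be excluded. The expected step is a 1.6-fold lower number from compound 1 to compound 4 (0.20 log units; within the scatter). Compound 4 is therefore estimated to give about 5000 nM, within a range from 1500 nM to 15000 nM.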

Compound 4, half-maximal inhibitory concentration: 1300 nM
For compound 4 the middle estimate is 3.8-fold (0.59 log units) above the measured one; measured number below the stated range.
By their numbers in this assay, from the lowest: compounds 2, 3 and 4 (each within the scatter of the next); then compound 1.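

In this assay, within the data shown here, phenyl in place of pyridin-4-yl gives a 6.1-fold lower number from compound 1 to compound 4 (0.79 log units; beyond the scatter), the first step that can be read at a single place. At this aromatic carbon, para to a hydroxy group, the number therefore responds to the exchange of one six-membered aromatic ring for another, with the ring nitrogen gone and the ring size and net charge unchanged. No measurement at hand bears on what lies behind this step.

On these data alone, it remains open how pyridin-3-yl, a saturated ring such as piperidin-4-yl, an amine or a carboxylic acid would read at the same carbon. As far as these compounds go, it is also open whether the step keeps its size when the nitrile of compound 1 and compound 4 gives way to another group, such as trifluoromethyl.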